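The source may report more compounds than this note shows. Statements on the series, on what has been measured and on what is new or still open speak of the compounds shown alone.

Measured so far in a functional assay on HSC-2 cells (Homo sapiens) for cytotoxicity; a higher number here means that more compound is tolerated, a lower number that less compound is tolerated:

- compound 1, `COc1cc(/C=C2\CCC/C(=C\c3ccc([N+](=O)[O-])cc3)C2=O)ccc1O`: compound 1 gives 2800 nM
- compound 2, `O=C1/C(=C/c2ccc(Cl)cc2)CCC/C1=C\c1ccc([N+](=O)[O-])cc1`: compound 2 gives 1500 nM

For the measured compounds named here, compound 2 has the lower of the two numbers, but the only measured step, a 1.9-fold lower number from compound 1 to compound 2 (0.27 log units; within the scatter), is within the scatter, so the two compounds cannot be told apart on these data.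

Compound 3, `O=C1/C(=C/c2ccc(O)cc2)CCC/C1=C\c1ccc([N+](=O)[O-])cc1`, differs from compound 2 by hydroxy in place of chloro on an aromatic carbon. Going by the values given here, this change is related to the one measured step: going from compound 1 to compound 2 replaced a phenyl carrying a hydroxy group with a chlorophenyl, and the number barely moved. Reversing that kind of swap, with the hydroxy group now standing alone on the ring, is therefore expected to give no step beyond the scatter in this assay, with the value for compound 3 expected to sit near those of compound 1 and compound 2.

The estimate for compound 3 is 2200 nM, within 900 nM to 5500 nM, which corresponds to an expected step of a 1.5-fold higher number from compound 2 to compound 3 (0.17 log units; within the scatter).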

Compound 3, half-maximal cytotoxic concentration: 8100 nM
The estimate for compound 3 lay 3.7-fold (0.57 log units) below the measured number; measured number above the stated range.
By their numbers in this assay, from the lowest: compounds 2 and 1 (each within the scatter of the next); then compound 3.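

In this assay, the group on this ring position does matter: hydroxy in place of chloro gives a 5.4-fold higher number from compound 2 to compound 3 (0.73 log units; beyond the scatter) and so moves the number beyond the scatter, which the earlier step of a 1.9-fold lower number from compound 1 to compound 2 (0.27 log units; within the scatter) did not do. Hydrogen in place of methoxy gives a 2.9-fold higher number from compound 1 to compound 3 (0.46 log units; beyond the scatter) as well, so the methoxy group next to nothing else in the comparison changes the outcome: a hydroxy ring separates from the chloro compound only when the methoxy group is absent. No measurement here accounts for either step.

As far as these compounds go, whether the higher number belongs to hydroxy in particular stays open, since an amine or a carboxylic acid at the same position could behave alike or differently. Compound 3 also leaves untested whether the same swap holds with the 4-nitrophenyl side changed.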